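Cytotoxicity of benzyl ether variants on the shared core

The source may report more compounds than this note shows. Statements on the series, on what has been measured and on what is new or still open speak of the compounds shown alone.

Three compounds share one core and differ only in the substituted phenyl on the saturated chain carbon bound to an oxygen on an aromatic ring. In an ADME assay on Huh-5-2 cells (Homo sapiens) for cytotoxicity, read by WST assay, with a stated time of 3 days (a lower number here means that less compound is tolerated, a higher number that more compound is tolerated), compound 1 `O=c1c(OCc2ccccc2Br)c(-c2ccccc2)oc2cc(O)cc(O)c12` gives 12000 nM, compound 2 `O=c1c(OCc2cccc(Br)c2)c(-c2ccccc2)oc2cc(O)cc(O)c12` gives 15000 nM, and compound 3 `Cc1cccc(COc2c(-c3ccccc3)oc3cc(O)cc(O)c3c2=O)c1` gives 29000 nM. The step of a 1.3-fold higher number from compound 1 to compound 2 (0.10 log units; within the scatter) and the step of a 1.9-fold higher number from compound 2 to compound 3 (0.29 log units; within the scatter) stay within the scatter, while a 2.4-fold higher number from compound 1 to compound 3 (0.38 log units; beyond the scatter) is modest but beyond it; compound 3 therefore carries the highest number of the three. Compound 4 `N#Cc1ccc(COc2c(-c3ccccc3)oc3cc(O)cc(O)c3c2=O)cc1` alters the same position again: 4-cyanophenyl in place of 3-methylphenyl on a saturated chain carbon bound to an oxygen on an aromatic ring. Among the measured compounds shown here, the steps that bear on this position, from compound 1 and from compound 2 to compound 3, were small, so no step beyond the scatter is expected, a 1.5-fold lower number from compound 3 to compound 4 (0.16 log units; within the scatter). Compound 4 is accordingly estimated at 20000 nM, within 8000 nM to 50000 nM.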

Compound 4, half-maximal cytotoxic concentration: 48000 nM
The estimate for compound 4 lay 2.4-fold (0.38 log units) below the measured number; low and high end bracket the measured number.
By their numbers in this assay, from the lowest: compounds 1, 2, 3 and 4 (each within the scatter of the next, the first and the last beyond it).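

In this assay the 4-cyanophenyl group stands clear of both bromophenyl groups, with a 4.0-fold higher number from compound 1 to compound 4 (0.60 log units; beyond the scatter) and a 3.2-fold higher number from compound 2 to compound 4 (0.51 log units; beyond the scatter) both beyond the scatter. Among the earlier compounds, only the step from compound 1 to compound 3 had done so. Against the 3-methylphenyl group the change stays within the scatter (a 1.7-fold higher number from compound 3 to compound 4 (0.22 log units; within the scatter)), so the nitrile does not set compound 4 apart from compound 3.

The compounds shown leave open whether the nitrile or its place on the ring goes with these numbers, which a 3-cyanophenyl or 4-methylphenyl group would address, and how an amine or a carboxylic acid would read here. No measurement at hand accounts for the result.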